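Trimethoxyphenyl pyrazolyl chalcones: cytotoxicity at a single concentration

The compounds below may be only part of what the source reports. "The series", "measured", "known", "first", "only" and "open" are said of these compounds alone.

Measured compounds, each with its value in a functional assay on NCI/ADR-RES cells (Homo sapiens) for cytotoxicity, read by sulforhodamine B assay, with a stated time of 48 h, tested at 0.01 uM; on this read-out lower numbers stand for a stronger effect and higher numbers for a weaker effect at the one concentration tested:

- compound 1, `COc1cc(-c2cc(/C=C/C(=O)c3ccc(N)cc3)[nH]n2)cc(OC)c1OC`, gives 106%
- compound 2, `COc1ccc(-c2cc(/C=C/C(=O)c3ccc(N)cc3)[nH]n2)cc1OC`, gives 102%
- compound 3, `COc1cc(C(=O)/C=C/c2cc(-c3cc(OC)c(OC)c(OC)c3)n[nH]2)cc(OC)c1OC`, gives 105%

All three values sit close together, and none of them can be told apart from the others on this read-out. Among the compounds with values here, the one counted change within the measured set is hydrogen in place of methoxy on an aromatic carbon, which gave a number 4 percentage points lower from compound 1 to compound 2 (within the scatter). Compound 3 and compound 1 differ in the arrangement of the shared core; the difference between the two cores is not broken down here.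

Compound 4, `COc1ccc(-c2cc(/C=C/C(=O)c3cc(OC)c(OC)c(OC)c3)[nH]n2)cc1OC`, has not been measured. Within the data shown here, it differs from compound 3 by hydrogen in place of methoxy on an aromatic carbon, the same change as the one from compound 1 to compound 2, at a place described in the same words. Among the measured compounds shown here, the step from compound 3 to compound 4 is therefore expected to be small, estimated as a number 2 percentage points lower from compound 3 to compound 4 (within the scatter), beside the earlier a number 4 percentage points lower from compound 1 to compound 2 (within the scatter), resting on the single measured example of this change. Compound 4 is expected to give about 103% in this assay, estimated to lie between 94% and 112%.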

Compound 4, a percentage reported as activity, at one concentration (the size of the read-out at that concentration, not a potency): 97%
Compound 4: middle estimate off by 6 percentage points, on the high side; the range from low to high includes it.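

In this assay, hydrogen in place of methoxy on an aromatic carbon gives a number 8 percentage points lower from compound 3 to compound 4 (within the scatter). Set beside the earlier step, the size of the change does not separate the two cores: the same change on two cores in this assay, a number 4 percentage points lower (within the scatter) from compound 1 to compound 2 and a number 8 percentage points lower (within the scatter) from compound 3 to compound 4, 4 percentage points apart, within the scatter of two such steps. This agrees with the change carrying from one core to the other in this read-out, but it does not show that the change has a real effect on either core, that the two steps are equal in size, or that the result would hold on any further core.

Still open, as far as these compounds go, is how a group other than methoxy or hydrogen at this place, such as a hydroxyl, a carboxylic acid or a longer alkoxy chain, would read in this assay. Also open is whether the two cores would separate under conditions where the read-out differs clearly among compounds, as the single concentration shown gives no potency.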